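Replacing Anilino With Azetidinyl on the Shared Core

The compounds below may be only part of what the source reports. "The series", "measured", "known", "first", "only" and "open" are said of these compounds alone.

Compound 1 `O=C1C(Nc2ccccc2)=CC(=O)c2c1nc1n2[C@H]2OC[C@@H](O)[C@H]2OC1` gives 3560 nM in a functional assay on ECa-109 cells for inhibition, with ECa-109 cell line (Homo sapiens) as the target, read by sulforhodamine B assay; a higher number here means a weaker inhibitor, a lower number a stronger inhibitor.
Compound 3 `O=C1C=C(Nc2ccc(Br)cc2)C(=O)c2c1nc1n2[C@H]2OC[C@@H](O)[C@H]2OC1` gives 2850 nM in this assay.
Compound 2 `COc1ccccc1NC1=CC(=O)c2nc3n(c2C1=O)[C@H]1OC[C@@H](O)[C@H]1OC3` gives only a limit of the assay, > 4000 nM, in this assay.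

Among the numbers shown, compound 1 holds the highest of the two, with compound 3 nearest at a gap that lies within the scatter; the third value is a limit. Compound 4 `O=C1C(N2CCC2)=CC(=O)c2c1nc1n2[C@H]2OC[C@@H](O)[C@H]2OC1` carries azetidin-1-yl in place of anilino on a double-bonded ring carbon. Within the data shown here, the only measured step, an at least 1.4-fold lower number from compound 2 to compound 3 (0.14 log units; that floor lies within the scatter), exchanges 2-methoxyphenyl for 4-bromophenyl on the amine nitrogen and stays within the scatter; no measured step replaces an aromatic ring with a four-membered non-aromatic ring, so it bears only loosely on this change. Compound 4 is therefore expected to sit near compound 1, with a 1.0-fold lower number from compound 1 to compound 4 (0.01 log units; within the scatter). For compound 4 the estimate is 3500 nM, ranging from 1500 nM to 8000 nM.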

Compound 4, half-maximal inhibitory concentration: > 16000 nM
Compound 4: a limit, no number; the forecaster's own chance of this, stated with the estimate: 35%; middle value at least 4.5-fold (0.66 log units) away from the limit.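

Azetidin-1-yl in place of anilino on the double-bonded ring carbon gives an at least 4.4-fold higher number from compound 1 to compound 4 (0.65 log units; beyond the scatter), the first step at this position that lies beyond the scatter. The compounds with an aryl group on the amine nitrogen had shown only a step within the scatter, so the nature of this substituent does matter in this assay. The reading for compound 4 is a limit, not a number: the limit of > 16000 nM in this assay, at which 1 of the 4 values shown sits.

The change removes both the aromatic ring and the hydrogen-bond donor, and the compounds shown leave open which of these matters. A cyclobutylamino group, keeping the amine hydrogen without an aromatic ring, would separate the two.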